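The source may report more compounds than this note shows. Statements on the series, on what has been measured and on what is new or still open speak of the compounds shown alone.

Compounds measured in an assay on isolated protein for inhibition of Gonadotropin-releasing hormone receptor (Homo sapiens); on this read-out lower numbers stand for stronger inhibition and higher numbers for weaker inhibition:
- compound 1 `Cc1cccc(CSc2nc3cc(NC(=O)C4CC4)ccc3n2C(C)C)c1`: 6500 nM
- compound 2 `COc1ccc([N+](=O)[O-])cc1CSc1nc2cc(NC(=O)NC(C)(C)C)ccc2n1C1CC1`: 79 nM
- compound 3 `COc1ccc([N+](=O)[O-])cc1CSc1nc2cc(NC(=O)C(C)(C)C)ccc2n1C(C)C`: 180 nM

Among these three numbers, compound 3 stands second highest. Its nearest neighbour is compound 2, whose number is lower by a gap beyond the scatter, and its furthest is compound 1, whose number is far higher, also beyond the scatter. Compound 4 `COc1ccc([N+](=O)[O-])cc1CSc1nc2cc(NC(=O)NC(C)C)ccc2n1C(C)C` has not been measured in this assay. It differs from compound 3 in one place: isopropylamino in place of tert-butyl on a carbonyl carbon. Going by the values given here, no measured pair shows this exact change, so the size of its effect is unknown. Because compound 3 gives 180 nM and the change is small in atom count, the step is expected to be modest, likely within the scatter or a slight lowering, so a 1.5-fold lower number from compound 3 to compound 4 (0.18 log units; within the scatter) is the estimate. Compound 4 is therefore expected to give 120 nM, with a range from 40 nM to 400 nM.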

Compound 4, half-maximal inhibitory concentration: 600 nM
Compound 4: middle estimate off by 5.0-fold (0.70 log units), on the low side; the whole stated range lies below it.
By their numbers in this assay, from the lowest: compound 2; then compound 3; then compound 4; then compound 1.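

In this assay, going from (tert-butyl)carbonyl to isopropylcarbamoyl gives a 3.3-fold higher number from compound 3 to compound 4 (0.52 log units; beyond the scatter). The two groups have the same count of heavy atoms, but the entering one adds a nitrogen and a hydrogen-bond donor, so this position can shift the number even when the size of the group, counted in heavy atoms, stays the same. Nothing measured here gives a reason for this step.

Still open, from the compounds shown here alone, is whether the nitrogen or the change in the carbon branching matters more. An isopropyl group set directly on that carbonyl carbon would help separate the two, and a morpholine there would test a ring at this position.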